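This account rests on a few compounds, and the source may have more. Where it says the series, first, only, none or still open, it means among the compounds named here.

In a functional assay on the whole organism for antagonist activity, with Mus musculus as the target, at a dose of 3 mg/kg by the oral route (on this read-out higher numbers stand for a stronger effect at the one dose given and lower numbers for a weaker effect), compound 3 `C[C@]1(c2ccc(O)cc2)CSc2cc(O)ccc2[C@H]1CCCCCCCCC(CCCCC(F)(F)C(F)(F)F)C(=O)O` gives 69%. Compound 2 `C[C@]1(c2ccc(O)cc2)CSc2cc(O)ccc2[C@H]1CCCCCCCCC(CCC(F)(F)C(F)(F)C(F)(F)C(F)(F)F)C(=O)O` gives 63% in this assay, and compound 1 `C[C@]1(c2ccc(O)cc2)CSc2cc(O)ccc2[C@H]1CCCCCCCCC(CCCC(F)(F)C(F)(F)F)C(=O)O` gives 41%. Compound 3 thus holds the highest of the three numbers, though its gap to compound 2 lies within the usual scatter of repeated measurements, while its gap to compound 1 lies beyond it.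

Compound 4 `C[C@]1(c2ccc(O)cc2)CSc2cc(O)ccc2[C@H]1CCCCCCCCC(CCCCCC(F)(F)C(F)(F)F)C(=O)O` has not yet been measured. It differs from compound 3 in one place: 2,2,3,3,3-pentafluoropropyl in place of 1,1,2,2,2-pentafluoroethyl on a saturated chain carbon, five bonds along the chain from a carbonyl carbon. Within the data shown here, one measured step bears directly on this change: a number 28 percentage points higher from compound 1 to compound 3 (beyond the scatter), where the same pentafluoropropyl-for-pentafluoroethyl exchange was made one bond closer to the carbonyl carbon. That step was a modest rise. With compound 3 already at the top of the measured range, a gain of the same size seems less likely, but the direction is expected to be upward or flat rather than downward.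

Compound 4 is therefore expected to give about 74% in this assay, with a likely range from 56% to 90%. The expected step is a number 5 percentage points higher from compound 3 to compound 4 (within the scatter), a small rise that may not exceed the scatter.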

Compound 4, a percentage reported as inhibition, in the whole organism at one dose (the size of the read-out at that dose, not a potency): 52%
Estimate against measurement, compound 4: 22 percentage points above, and the stated range ends above it.
By their numbers in this assay, from the lowest: compound 1; then compound 4; then compounds 2 and 3 (each within the scatter of the next).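

In this assay, the exchange of 1,1,2,2,2-pentafluoroethyl for 2,2,3,3,3-pentafluoropropyl does not act the same way at each place: four bonds along the chain from a carbonyl carbon it gives a number 28 percentage points higher from compound 1 to compound 3 (beyond the scatter), whereas five bonds along it gives a number 17 percentage points lower from compound 3 to compound 4 (beyond the scatter). Compound 4 nevertheless keeps part of the earlier gain, with a number 11 percentage points higher from compound 1 to compound 4 (beyond the scatter), so across compounds 1, 3 and 4 the number rises and then falls as the chain grows, which is a turn rather than a steady trend. Nothing measured here accounts for this turn.

The compounds shown leave open whether a still longer chain ending in the same pentafluoroethyl group would fall further. They also leave open how a chain ending in trifluoromethyl, or one with no fluorine at all, would behave at these lengths.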